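Phenylsulfonyl for 4-cyanophenoxy on a piperidine chain

The source may report more compounds than this note shows. Statements on the series, on what has been measured and on what is new or still open speak of the compounds shown alone.

Two compounds in this set share a piperidine bearing a diarylmethyl group, with a three-carbon chain on the ring nitrogen. Compound 1 `COc1cc(C(C)=O)ccc1OCCCN1CCC(C(c2ccc(F)cc2)c2ccc(F)c(F)c2)CC1` carries a substituted aryl ether at the end of that chain, and in a functional assay (aorta) with Oryctolagus cuniculus as the target (on this read-out higher numbers stand for weaker binding and lower numbers for tighter binding), compound 1 gives 1.26 nM. Compound 2 `N#Cc1ccc(OCCCN2CCC(C(c3ccc(F)cc3)c3ccc(F)cc3)CC2)cc1` carries a 4-cyanophenoxy group there, and in this assay compound 2 gives 5.01 nM. Of the two numbers measured, compound 2 has the higher one, and the gap to compound 1 lies beyond the usual scatter; since the two differ in more than one place, nothing more than the two values themselves can be read from that.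

Compound 3 `O=S(=O)(CCCN1CCC(C(c2ccc(F)cc2)c2ccc(F)cc2)CC1)c1ccccc1` is not yet measured. It differs from compound 2 in one place: phenylsulfonyl in place of 4-cyanophenoxy on a saturated chain carbon, three bonds along the chain from an amine nitrogen in a ring. Among the compounds with values here, no measured pair shows this exchange, so there is no step to lean on. The expectation is that the step of a 1.3-fold higher number from compound 2 to compound 3 (0.10 log units; within the scatter) stays modest and within the scatter, as both groups have the same count of heavy atoms and acceptors. For compound 3 in this assay the estimate is 6.3 nM, with a range from 1.6 nM to 25 nM.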

Compound 3, dissociation constant: 20 nM
Compound 3: middle estimate off by 3.2-fold (0.50 log units), on the low side; low and high end bracket the measured number.
By their numbers in this assay, from the lowest: compound 1; then compound 2; then compound 3.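

On this saturated chain carbon, three bonds along the chain from an amine nitrogen in a ring, phenylsulfonyl in place of 4-cyanophenoxy gives a 4.0-fold higher number from compound 2 to compound 3 (0.60 log units; beyond the scatter) in this assay. Within the data shown here, this is the first comparison in the set that changes one place only, and it shows that the number responds to the group at this position. Matching counts of heavy atoms and hydrogen-bond acceptors, and one six-membered aromatic ring in each group, did not hold the number within the scatter, and nothing measured here bears on why it moved.

The single exchange removes the ether oxygen and the nitrile and brings in the sulfonyl group at once, so the compounds shown cannot separate these changes; plain phenoxy or 4-cyanophenylsulfonyl at the same place would bear on that. Also open, from the compounds shown here alone, is whether a benzoyl group or a longer chain would give a number closer to that of compound 2, and whether the same exchange would give a similar step on the core of compound 1.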